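The source may hold more compounds than are shown below. What is called first, only, known or untested is meant among the compounds shown, and "the series" means these compounds.

Measured so far in a functional assay on MCF7 cells (Homo sapiens) for antiproliferative activity, read by sulforhodamine B assay, with a stated time of 48 h; on this read-out higher numbers stand for weaker inhibition and lower numbers for stronger inhibition:

- Compound 1 `COc1cccc(/C=C/C(=O)/C=C(O)/C=C/c2cccc(OC)c2OC)c1OC` gives > 50000 nM as a limit only
- Compound 2 `COc1ccc(OC)c(/C=C/C(=O)/C=C(O)/C=C/c2cc(OC)ccc2OC)c1` gives > 50000 nM as a limit only
- Compound 3 `COc1cccc(/C=C/C(=O)C(=Cc2ccc(F)cc2)C(=O)/C=C/c2cccc(OC)c2OC)c1OC` gives 1830 nM as a true number

For the measured compounds named here, compound 3 at 1830 nM holds the only number so far. The other values stand at the limit of > 50000 nM in this assay, at which 2 of the 3 values shown sit, and are not numbers.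

Compound 4 `COc1cc(C=C(C(=O)/C=C/c2cccc(OC)c2OC)C(=O)/C=C/c2cccc(OC)c2OC)ccc1O` has not yet been measured. Compared with compound 3 it has 4-hydroxy-3-methoxyphenyl in place of 4-fluorophenyl on a double-bonded chain carbon bound to a double-bonded chain carbon as its one change.

Going by the values given here, no measured pair shows what this swap does. The closest guide is compound 3 at 1830 nM so no shift beyond the usual scatter is expected. The expected step of a 1.1-fold higher number from compound 3 to compound 4 (0.04 log units; within the scatter) is therefore small, with no clear direction. For compound 4 the estimated value is 2000 nM with an expected range from 600 nM to 7000 nM in this assay.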

Compound 4, half-maximal inhibitory concentration: 480 nM
Compound 4: middle estimate off by 4.2-fold (0.62 log units), on the high side; measured number below the stated range.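

In this assay, placing 4-hydroxy-3-methoxyphenyl in place of 4-fluorophenyl on a double-bonded chain carbon bound to a double-bonded chain carbon gives a 3.8-fold lower number from compound 3 to compound 4 (0.58 log units; beyond the scatter), which means stronger inhibition. For the compounds shown here, this is the first sign that activity responds to the group at this position, and the aromatic ring can carry a hydroxy and a methoxy group without losing activity. Nothing shown explains why the change helps.

As far as these compounds go, the hydroxy and methoxy groups enter together, so their separate contributions remain open. From the compounds shown here alone, how an amine or a carboxylic acid on this ring would behave is also open.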